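Trading an amino group for a hydroxy group

The source may hold more compounds than are shown below. What is called first, only, known or untested is meant among the compounds shown, and "the series" means these compounds.

In a functional assay on the whole organism (strain Sprague-Dawley) for inhibition, with Rattus norvegicus as the target, with a stated time of 10 min (on this read-out higher numbers stand for an effect only at larger amounts of compound and lower numbers for an effect already at smaller amounts), compound 1 (`O=C(O)c1cnc(-c2ccccc2)[nH]c1=O`) gives 50 mg/kg as its dose. Compound 2 (`O=C(O)c1cnc(-c2ccccc2[N+](=O)[O-])[nH]c1=O`) bears a nitro group in place of a hydrogen on an aromatic carbon. For compound 2 the result > 50 mg/kg is a limit and not a number. Compound 3 (`Nc1ccccc1-c1ncc(C(=O)O)c(=O)[nH]1`) bears an amino group instead and gives 50 mg/kg as its dose, level with compound 1 at the digits shown.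

The next compound, compound 4 (`O=C(O)c1cnc(-c2ccccc2O)[nH]c1=O`), puts hydroxy in place of amino on an aromatic carbon, ortho to a large group (hydroxy in place of amino on an aromatic carbon). For the measured compounds named here, no measured step makes this exact exchange. The closest guide is the arrival of the amino group, which gave no change at the digits printed from compound 1 to compound 3 (within the scatter) and so moved nothing beyond the scatter. The steps that involve compound 2 (a number no lower from compound 1 to compound 2 (the limit leaves the size open) and a number no higher from compound 2 to compound 3 (the limit leaves the size open)) rest on a limit and show a direction but no size. On that evidence, no shift beyond the scatter is expected in this assay in either direction. The expected step is no change at the digits printed from compound 3 to compound 4 (within the scatter) at this stage. Compound 4 is estimated at 50 mg/kg with an expected range of 25 mg/kg to 100 mg/kg as its dose.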

Compound 4, dose for 50% inhibition: > 5 mg/kg
Compound 4 was reported as a limit; the forecaster's own chance of this, stated with the estimate: 35%; the middle value does not contradict the limit.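

In this assay compound 4 gives > 5 mg/kg, which is a limit and not a number. The steps to compound 4 from compound 1, compound 2 and compound 3 therefore cannot be read. The compounds shown leave open whether hydroxy in place of amino shifts the dose at all, and in which direction.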